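From butyl to propyl on the side chain

A few compounds are considered here, and "the series" means these few. Any claim that something is new, unique, unknown or untested is made for them only; others in the source may bear on it.

- compound 1 `CC(C)=CC[C@@H](OC(=O)CCO)C1=CC(=O)c2c(O)ccc(O)c2C1=O`: 55300 nM
- compound 2 `CCCCC(O)CC(=O)O[C@H](CC=C(C)C)C1=CC(=O)c2c(O)ccc(O)c2C1=O`: 45300 nM
- compound 3 `CCCCC(CC(=O)O[C@H](CC=C(C)C)C1=CC(=O)c2c(O)ccc(O)c2C1=O)OC(C)=O`: 67700 nM

These three values come from a functional assay on DU-145 cells (Homo sapiens) for cytotoxicity, read by MTT assay; a lower number here means a stronger inhibitor, a higher number a weaker inhibitor. Compound 3 is not separated from the other two, since a 1.2-fold higher number from compound 1 to compound 3 (0.09 log units; within the scatter) and a 1.5-fold higher number from compound 2 to compound 3 (0.17 log units; within the scatter) both stay within the scatter. Compound 4 `CCCC(CC(=O)O[C@H](CC=C(C)C)C1=CC(=O)c2c(O)ccc(O)c2C1=O)OC(C)=O` differs from compound 3 by hydrogen in place of methyl on a saturated chain carbon, four bonds along the chain from an oxygen next to a carbonyl group, so that butyl becomes propyl.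

For the measured compounds named here, no measured step isolates this change. The closest is a 1.2-fold lower number from compound 1 to compound 2 (0.09 log units; within the scatter), where an entire butyl group enters, and it too stays within the scatter. Acetyl in place of hydrogen gives a 1.5-fold higher number from compound 2 to compound 3 (0.17 log units; within the scatter), again within the scatter. The change at hand removes only part of that butyl group, so no step beyond the scatter is expected in this assay, and no direction can be favoured. The estimated step is a 1.1-fold lower number from compound 3 to compound 4 (0.04 log units; within the scatter). For compound 4 the expected value is 62000 nM, with an estimated range of 35000 nM to 100000 nM.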

Compound 4, half-maximal inhibitory concentration: 55700 nM
Compound 4: the middle estimate sits 1.1-fold (0.05 log units) above what was measured; measured number inside the range.
By their numbers in this assay, from the lowest: compounds 2, 1, 4 and 3 (each within the scatter of the next).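

In this assay, for the compounds shown here, a 1.2-fold lower number from compound 3 to compound 4 (0.08 log units; within the scatter) is the first step to isolate the length of this chain, on a saturated chain carbon, four bonds along the chain from an oxygen next to a carbonyl group, and butyl to propyl there does not separate the two compounds. The larger exchanges ending in the propyl compound also remain within the scatter, with a 1.2-fold higher number from compound 2 to compound 4 (0.09 log units; within the scatter) for 1-acetoxybutyl in place of 1-hydroxypentyl and a 1.0-fold higher number from compound 1 to compound 4 (0.00 log units; within the scatter) for 1-acetoxybutyl in place of hydroxymethyl. No supporting evidence bears on this result.

The compounds shown leave open whether an amine, a carboxylic acid or a longer chain at this position would give a step beyond the scatter. They also leave open whether acetyl matters when the chain is propyl.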